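The source may report more compounds than this note shows. Statements on the series, on what has been measured and on what is new or still open speak of the compounds shown alone.

Compound 1 `CC(C)c1onc(-c2c(Cl)cccc2Cl)c1COc1ccc(-c2nc3ccc(C(=O)O)cc3n2C(C)C)cc1` carries an isopropyl group on an aromatic nitrogen of its shared core. In an assay on isolated protein for agonist activity at Bile acid receptor (Homo sapiens), read by TR-FRET (a lower number here means that less compound is needed, a higher number that more compound is needed for the effect), compound 1 gives 56.7 nM. Compound 2 `CC(C)c1onc(-c2c(Cl)cccc2Cl)c1COc1ccc(-c2nc3ccc(C(=O)O)cc3n2C2CC2)cc1` differs only in that place, and in this assay compound 2 gives 117 nM; the step is a 2.1-fold higher number from compound 1 to compound 2 (0.31 log units; beyond the scatter). Compound 3 `CC(C)c1onc(-c2c(Cl)cccc2Cl)c1COc1ccc(-c2nc3ccc(C(=O)O)cc3n2C2CCC2)cc1` has a cyclobutyl group in the same place, but in this assay compound 3 gives "not determined" (no result reported), so it stands nowhere on the numbers shown. Compound 4 `CC(C)c1onc(-c2c(Cl)cccc2Cl)c1COc1ccc(-c2nc3ccc(C(=O)O)cc3n2Cc2ccc(F)cc2)cc1` is the next change: 4-fluorobenzyl in place of cyclobutyl on an aromatic nitrogen. Among the compounds with values here, only the step from compound 1 to compound 2 bears on this, and it was modest; for a change of this size no firm direction can be read from it. For compound 4 the expected value in this assay is 150 nM, with a range from 40 nM to 600 nM.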

Compound 4, half-maximal effective concentration: 105 nM
Compound 4: the middle estimate sits 1.4-fold (0.15 log units) above what was measured; low and high end bracket the measured number.
By their numbers in this assay, from the lowest: compounds 1, 4 and 2 (each within the scatter of the next, the first and the last beyond it).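

In this assay, 4-fluorobenzyl, with 8 heavy atoms and a six-membered aromatic ring, gives a number that cannot be told apart from those with the two smaller groups: a 1.1-fold lower number from compound 2 to compound 4 (0.05 log units; within the scatter) and a 1.9-fold higher number from compound 1 to compound 4 (0.27 log units; within the scatter). So this place on the aromatic nitrogen accepts an aromatic ring without a change beyond the scatter. The step from compound 3 to compound 4 cannot be read, and no measured evidence here explains the result.

Still open, as far as these compounds go, is whether plain benzyl, without the fluorine, would give a similar number. The same goes for a longer chain or a group carrying an amine at this place.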